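Working notes on a single substituent change

This account rests on a few compounds, and the source may have more. Where it says the series, first, only, none or still open, it means among the compounds named here.

Of the compounds shown here, two carry numbers so far. Compound 1 `COc1ccc(-c2csc(N)c2C(=O)OCc2ccccc2)cc1OC` gives 100% in an assay on isolated protein for inhibition of protein kinase C zeta type (Homo sapiens), with stated times of 1 h and 2.5 min, tested at 30 uM; on this read-out lower numbers stand for less inhibition and higher numbers for more inhibition at the one concentration tested (going by the name of the read-out). Compound 2 `Cc1ccc(-c2csc(N)c2C(=O)OCc2ccccc2)cc1` gives 60% in this assay. Within the data shown here, on these two numbers compound 2 stands lowest; its only neighbour is compound 1, whose number lies above it by a gap beyond the usual scatter. Among the measured compounds shown here, no single-point step between the two measured compounds is recorded, so the pair says only that the dimethoxy-bearing compound 1 reads high and the methyl-bearing compound 2 reads lower.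

Compound 3 `COc1ccc(-c2csc(N)c2C(=O)OCc2ccccc2)cc1` awaits measurement in this assay. It differs from compound 2 in one place: methoxy in place of methyl on an aromatic carbon. The structural change moves compound 3 part of the way toward compound 1, and because compound 1 gives 100% a step upward from compound 2 is expected, of moderate size and likely beyond the scatter, estimated as a number 20 percentage points higher from compound 2 to compound 3 (beyond the scatter). Compound 3 is accordingly expected to give about 80% in this assay, within a range from 55% to 100%.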

Compound 3, a percentage reported as inhibition, at one concentration (the size of the read-out at that concentration, not a potency): 86%
Estimate against measurement, compound 3: 6 percentage points below; low and high end bracket the measured number.
By their numbers in this assay, from the lowest: compound 2; then compound 3; then compound 1.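

Among these compounds, at the aromatic carbon para to a large group, the change from 4-methylphenyl to 4-methoxyphenyl now has a single-place reading in this assay, with a number 26 percentage points higher from compound 2 to compound 3 (beyond the scatter); the earlier pair of compounds could not isolate this change, since no step between them was recorded. A second single-place comparison, a number 14 percentage points lower from compound 1 to compound 3 (beyond the scatter), shows that hydrogen in place of one methoxy of compound 1 also lowers the reading, so the methoxy present in compound 3 does not alone account for the number of compound 1, and in both steps the compound with more methoxy groups reads higher. Nothing in hand bears on the reason for either step.

The compounds shown leave open whether another group at the same place, such as an ethoxy, a hydroxyl or an amine, would read above or below methoxy, and whether the trend extends beyond these three compounds. They also leave open how the reading would respond to a carboxylic acid or an amide in place of the ester on the shared core, and how these single-concentration readings relate to potency.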